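The compounds below may be only part of what the source reports. "The series", "measured", "known", "first", "only" and "open" are said of these compounds alone.

The measured compounds:
compound 1, `O=c1ccn(CCCCCOc2ccc(Cl)cc2)c(=O)[nH]1`; in an ADME assay on HEL cells (Homo sapiens) for cytotoxicity, read by microscopy (a higher number here means that more compound is tolerated, a lower number that less compound is tolerated), compound 1 gives > 100000 nM, which is a limit of the assay.
compound 2, `Cc1ccccc1OCCCCCn1ccc(=O)[nH]c1=O`; compound 2 gives > 100000 nM, likewise a limit.
compound 3, `O=c1ccn(CCCCCOc2ccccc2)c(=O)[nH]1`; compound 3 gives > 100000 nM, also a limit.

Among the compounds with values here, compound 3 therefore stands where every compound so far stands, at the limit of > 100000 nM in this assay, at which 3 of the 3 values shown sit. As far as these compounds go, none of the steps among the three can be read: a step that the two limits leave unreadable from compound 1 to compound 2, a step that the two limits leave unreadable from compound 1 to compound 3 and a step that the two limits leave unreadable from compound 2 to compound 3 each run from one limit to another, so their sizes are unknown.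

Compound 4, `Cc1cccc(OCCCCCn2ccc(=O)[nH]c2=O)c1`, is not yet measured. It differs from compound 3 by methyl in place of hydrogen on an aromatic carbon. Within the data shown here, the closest measured comparison is the step from compound 2 to compound 3, which also concerns a methyl on an aromatic carbon, but it is unreadable, as are the other two; no measured step can therefore give a size or a direction for this change. Since compound 3 sits at the limit, compound 4 is expected to remain at or near that limit, an estimated 120000 nM with a range of 50000 nM to 400000 nM. The step this estimate means is a step that the limit leaves unreadable from compound 3 to compound 4, expected to fall within the scatter.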

Compound 4, minimum cytotoxic concentration: > 100000 nM
Compound 4 was reported as a limit; the forecaster's own chance of this, stated with the estimate: 85%; the middle value does not contradict the limit.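

Within the data shown here, compound 4 sits at a limit, as do compound 1, compound 2 and compound 3, so no step from any of them to compound 4 can be read: the limit of > 100000 nM in this assay, at which 4 of the 4 values shown sit. The compounds shown leave open at what concentration, if any, cytotoxicity would appear in this assay and whether these ring changes alter it.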